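Added chloro on two related cores: cytotoxicity notes

The source may report more compounds than this note shows. Statements on the series, on what has been measured and on what is new or still open speak of the compounds shown alone.

Measured in an ADME assay on CHO-K1 cells (Cricetulus griseus) for cytotoxicity, read by MTT assay, with a stated time of 24 h; on this read-out higher numbers stand for weaker inhibition and lower numbers for stronger inhibition:
compound 1 `O=[N+]([O-])c1cc(CSc2nnnn2Cc2ccc(Cl)cc2)cc([N+](=O)[O-])c1` gives 94000 nM
compound 2 `O=[N+]([O-])c1cc(CSc2nnnn2Cc2ccc(Cl)c(Cl)c2)cc([N+](=O)[O-])c1` gives 140000 nM
compound 3 `O=[N+]([O-])c1cc(CSc2nnn(Cc3ccc(Cl)cc3)n2)cc([N+](=O)[O-])c1` gives 301000 nM

Compound 1 and compound 2 differ by one change, (chloro in place of hydrogen on an aromatic carbon), and this gave a 1.5-fold higher number from compound 1 to compound 2 (0.17 log units; within the scatter); the two numbers are thus within the scatter of each other, and no order between them is claimed.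

Compound 3 has the same atoms as compound 1, joined differently; the difference between the two cores is not broken down here. Compound 3 carries the highest of the three numbers, and its gaps to compound 2 and to compound 1 both lie beyond the scatter.

Compound 4 `O=[N+]([O-])c1cc(CSc2nnn(Cc3ccc(Cl)c(Cl)c3)n2)cc([N+](=O)[O-])c1` is not yet measured. It stands to compound 3 as compound 2 stands to compound 1: the change is chloro in place of hydrogen on an aromatic carbon, and the surroundings of the place are the same word for word in both pairs, so this is the same change, made on the core of compound 3 rather than that of compound 1.

In this assay, within the data shown here, the step from compound 3 to compound 4 is expected to be a 1.5-fold higher number from compound 3 to compound 4 (0.17 log units; within the scatter), resting on the single earlier step of a 1.5-fold higher number from compound 1 to compound 2 (0.17 log units; within the scatter), which was within the scatter. Compound 4 is therefore estimated at 450000 nM, with a plausible range from 200000 nM to 1000000 nM. The high numbers of this series leave some chance that only a limit is reported.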

Compound 4, half-maximal inhibitory concentration: 150000 nM
Compound 4: middle estimate off by 3.0-fold (0.48 log units), on the high side, and the stated range ends above it.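

Among these compounds, on the second core, this assay gives a 2.0-fold lower number from compound 3 to compound 4 (0.30 log units; within the scatter), and no order within that pair is claimed. Set beside the earlier step, the same change does not read the same on the two cores: the same change on two cores in this assay, a 1.5-fold higher number (0.17 log units; within the scatter) from compound 1 to compound 2 and a 2.0-fold lower number (0.30 log units; within the scatter) from compound 3 to compound 4, 3.0-fold (0.48 log units) apart, beyond the scatter of two such steps. This shows that the step measured on the first core was not a safe guide to the step on the second core in this series, but with one pair per core, and each step within the scatter on its own, it does not show a settled direction for the change on either core, nor does it explain why the two steps part.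

The compounds shown leave open whether a different group entering at the same place on the 4-chlorobenzyl group, such as an amine or a carboxylic acid, would give matching steps on the two cores. From the compounds shown here alone, it also remains open whether a gap of this size between the cores is particular to the change from 4-chlorobenzyl to 3,4-dichlorobenzyl or recurs with other changes, since this single matched comparison is all that is in hand.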